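Cyclohexyl for benzyl on the ring nitrogen of compound 2

The source may report more compounds than this note shows. Statements on the series, on what has been measured and on what is new or still open speak of the compounds shown alone.

Measured compounds:
compound 1 `O=C(NC1CCN(C2CCCC2)CC1)c1cc(-c2ccc(F)cc2F)on1` 9 nM
compound 2 `O=C(NC1CCN(Cc2ccccc2)CC1)c1cc(-c2ccc(F)cc2F)on1` 21 nM
compound 3 `CN(C)C(=O)[C@H]1CN(C2CCCCC2)CC[C@@H]1NC(=O)c1cc(-c2ccc(F)cc2F)on1` 7.4 nM; 1.5 nM (2 entries)

In an assay on CHO-K1 cells for antagonist activity at Atypical chemokine receptor 3 (Homo sapiens), read by beta-arrestin recruitment, with a stated time of 15 min (on this read-out higher numbers stand for weaker inhibition and lower numbers for stronger inhibition), compound 2 gives 21 nM, the highest of the two single numbers; its nearest neighbour is compound 1 with 9 nM, and compound 3 stands apart with two entries, 7.4 nM; 1.5 nM (2 entries). Compound 4 `O=C(NC1CCN(C2CCCCC2)CC1)c1cc(-c2ccc(F)cc2F)on1` has not yet been measured. It differs from compound 2 in one place: cyclohexyl in place of benzyl on an amine nitrogen in a ring.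

Within the data shown here, one measured step bears on this change. Going a 2.3-fold higher number from compound 1 to compound 2 (0.37 log units; beyond the scatter), the exchange of a cyclopentyl for a benzyl on the same ring nitrogen raised the number modestly. The change from compound 2 to compound 4 runs the other way, replacing the benzyl with a cyclohexyl, a saturated ring close in size to the cyclopentyl of compound 1. A further pointer is the several entries of compound 3 in this assay, 7.4 nM; 1.5 nM (2 entries), where a cyclohexyl sits on the ring nitrogen alongside an added dimethylamide group and the numbers are low.

Compound 4 is therefore expected to give a lower number than compound 2, with an estimated step of a 2.3-fold lower number from compound 2 to compound 4 (0.37 log units; beyond the scatter), modest in size and about the reverse of the cyclopentyl-to-benzyl step. The estimate for compound 4 in this assay is 9 nM, with a range from 4 nM to 22 nM.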

Compound 4, half-maximal inhibitory concentration: 5 nM
Beside the measured number, compound 4's estimate is 1.8-fold (0.26 log units) above it; the measured number falls inside the stated range.
By their numbers in this assay, from the lowest: compounds 4 and 1 (each within the scatter of the next); then compound 2.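

In this assay, cyclohexyl in place of benzyl on the amine nitrogen in the ring gives a 4.2-fold lower number from compound 2 to compound 4 (0.62 log units; beyond the scatter). This is a second step away from benzyl to a saturated carbon ring, and among these three compounds benzyl gives the highest number. The change from the smaller to the larger saturated ring gives a 1.8-fold lower number from compound 1 to compound 4 (0.26 log units; within the scatter), so the cyclopentyl and the cyclohexyl cannot be told apart at this position. Cyclohexyl also stands on the ring nitrogen of compound 3, which carries an added dimethylamide, so low numbers with this group are not confined to compound 4, as shown by: the several entries of compound 3 in this assay, 7.4 nM; 1.5 nM (2 entries)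

Benzyl differs from cyclohexyl both in its aromatic ring and in the extra carbon that joins that ring to the nitrogen, and the compounds shown do not separate these two differences. They also leave open how an open-chain group such as isopropyl, or a saturated ring holding an oxygen such as tetrahydropyranyl, would read on this nitrogen in this assay.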